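This account rests on a few compounds, and the source may have more. Where it says the series, first, only, none or still open, it means among the compounds named here.

Measured so far:
- compound 1 `S=C(NCc1ccccc1)C1(c2ccccn2)CCCS1`: <= 30 mg/kg (a limit, not a number)
- compound 2 `NC(=S)C1(c2ccccn2)SCCCS1`: 2.8 mg/kg

Both readings come from a functional assay on the whole organism (stomach) with Rattus norvegicus as the target; a higher number here means that more compound is needed for the effect, a lower number that less compound is needed. The entry for compound 1 is a limit of the assay. Among the measured compounds shown here, compound 2, at 2.8 mg/kg, holds the only actual number and is therefore the sole firm reference point.

The next compound is compound 3 `C/N=C(\S)C1(c2ccccn2)SCCCS1`. It differs from compound 2 by a group of 4 heavy atoms (2 carbon, 1 nitrogen, 1 sulfur; no ring) in place of a group of 3 heavy atoms (1 carbon, 1 nitrogen, 1 sulfur; no ring), on a saturated ring carbon.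

For the measured compounds named here, no measured step covers this kind of change. In this assay, a small step towards a higher dose is expected, probably not beyond the usual scatter. The expected change is a 1.8-fold higher number from compound 2 to compound 3 (0.25 log units; within the scatter). For compound 3 the estimate is 5 mg/kg, with an expected range from 1.5 mg/kg to 20 mg/kg.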

Compound 3, dose for half-maximal effect: 5.7 mg/kg
For compound 3 the middle estimate is 1.1-fold (0.06 log units) below the measured one; low and high end bracket the measured number.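

In this assay, the position on a saturated ring carbon between two ring sulfur atoms now has its first measured step, with the group of 4 heavy atoms in place of the group of 3 heavy atoms: a 2.0-fold higher number from compound 2 to compound 3 (0.31 log units; beyond the scatter). The step is modest but beyond the scatter, so this position responds to even a small change of group, and the larger group moves the number upward. Among the compounds shown here, compound 3 also gives the series a second actual number, and with it the first comparison between compounds that differ in one place.

For the compounds shown here, compound 1 remains a limit of the assay and gives no step: the limit of <= 30 mg/kg in this assay, at which 1 of the 3 values shown sits. Open, from the compounds shown here alone, is how a longer chain or a carboxylic acid at this position would read in this assay, and whether the same step would hold on another core.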